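4,4-Dimethylpiperidin-1-yl Gives Way to 4-Oxopiperidin-1-yl

The source may hold more compounds than are shown below. What is called first, only, known or untested is meant among the compounds shown, and "the series" means these compounds.

Measured so far in a functional assay on CHO-K1 cells for antagonist activity at transient receptor potential cation channel subfamily V member 1 (Homo sapiens), read by FLIPR; on this read-out higher numbers stand for weaker inhibition and lower numbers for stronger inhibition:
compound 1 `CCCCN(C)c1nc(C(F)(F)F)ccc1CNC(=O)C(C)c1ccc(NS(C)(=O)=O)c(F)c1`: 0.8 nM
compound 2 `CC(C(=O)NCc1ccc(C(F)(F)F)nc1N1CCC(C)(C)CC1)c1ccc(NS(C)(=O)=O)c(F)c1`: 0.3 nM

Compound 2 holds the lowest of the two numbers, and its nearest neighbour is compound 1, separated by a 2.7-fold lower number from compound 1 to compound 2 (0.43 log units; beyond the scatter). Compound 3 `CC(C(=O)NCc1ccc(C(F)(F)F)nc1N1CCC(=O)CC1)c1ccc(NS(C)(=O)=O)c(F)c1` changes compound 2 in one place: 4-oxopiperidin-1-yl in place of 4,4-dimethylpiperidin-1-yl on an aromatic carbon. Within the data shown here, no measured step covers this particular swap; the only precedent, a 2.7-fold lower number from compound 1 to compound 2 (0.43 log units; beyond the scatter), concerns a different group entering at the same aromatic carbon next to the ring nitrogen. The step is therefore expected to be small, with compound 3 estimated a little weaker: a 3.3-fold higher number from compound 2 to compound 3 (0.52 log units; beyond the scatter). Compound 3 is estimated at 1 nM, with a range from 0.2 nM to 5 nM.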

Compound 3, inhibition constant: 91 nM
The estimate for compound 3 lay 91-fold (1.96 log units) below the measured number; measured number outside the range, above it.
By their numbers in this assay, from the lowest: compound 2; then compound 1; then compound 3.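

The ketone version does not behave like the two earlier groups at this aromatic carbon: in this assay, replacing 4,4-dimethylpiperidin-1-yl with 4-oxopiperidin-1-yl gives a 300-fold higher number from compound 2 to compound 3 (2.48 log units; beyond the scatter), a large change from a small edit of the same six-membered ring. Replacing butyl(methyl)amino with the same group also gives a large change, a 110-fold higher number from compound 1 to compound 3 (2.06 log units; beyond the scatter), so the loss appears against both earlier groups. Nothing available explains this loss.

The compounds shown leave open whether the carbonyl oxygen itself or the absence of the dimethyl groups matters more. Plain piperidin-1-yl or 4-hydroxypiperidin-1-yl at this position could help separate the two.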